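The compounds below may be only part of what the source reports. "The series", "measured", "known", "first", "only" and "open" are said of these compounds alone.

Values in an ADME assay on ECV-304 cells (Homo sapiens) for cytotoxicity, read by MTT assay, with a stated time of 72 h; a higher number here means a weaker inhibitor, a lower number a stronger inhibitor:
compound 1 `COc1ccc(C2=C(c3cc(OC)c(OC)c(OC)c3)C(=O)C(O[SiH2]C(C)(C)C)C2)cc1OC(C)C`: > 100 ug/mL
compound 2 `COc1ccc(C2=C(c3cc(OC)c(OC)c(OC)c3)C(=O)CC2O)cc1O`: > 100 ug/mL
compound 3 `COc1ccc(C2=C(c3cc(OC)c(OC)c(OC)c3)C(=O)C(OC(C)=O)C2)cc1Cl`: 3.5 ug/mL

Compound 2 stands at the limit of > 100 ug/mL in this assay, at which 2 of the 3 values shown sit, so it has a limit and no number. Compound 4 `COc1ccc(C2=C(c3cc(OC)c(OC)c(OC)c3)C(=O)CC2O)cc1` differs from compound 2 in one place: hydrogen in place of hydroxy on an aromatic carbon. Here 3-hydroxy-4-methoxyphenyl becomes 4-methoxyphenyl. Among the compounds with values here, no measured pair isolates this change, so the expectation is tentative. Compound 3 gives 3.5 ug/mL, which shows that compounds of this family can give a number in this assay. A moderate step toward stronger inhibition is therefore expected, although compound 4 may also return only a limit. The expected change runs an at least 2.5-fold lower number from compound 2 to compound 4 (0.39 log units; beyond the scatter). For compound 4 the estimated value is 40 ug/mL, with an expected range of 8 ug/mL to 100 ug/mL.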

Compound 4, half-maximal inhibitory concentration: > 100 ug/mL
Compound 4 was reported as a limit; the forecaster's own chance of this, stated with the estimate: 40%; middle value at least 2.5-fold (0.39 log units) from the limit.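

In this assay, compound 2 and compound 4 both return only a limit, so no step can be read between them: the limit of > 100 ug/mL in this assay, at which 3 of the 4 values shown sit.

As far as these compounds go, whether hydrogen in place of hydroxy on the aromatic carbon changes the half-maximal inhibitory concentration at all remains open.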